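Propoxycarbonyl to benzyloxycarbonyl on compound 3

The source may hold more compounds than are shown below. What is called first, only, known or untested is meant among the compounds shown, and "the series" means these compounds.

Among the measured compounds shown here, in a functional assay on HT-29 cells (Homo sapiens) for antiproliferative activity, read by MTT assay, with a stated time of 48 h (on this read-out higher numbers stand for weaker inhibition of growth and lower numbers for stronger inhibition of growth), compound 3 `CCCOC(=O)N1N=C(c2ccc(OC)cc2)CC1c1cc(OC)c(OC)c(OC)c1` gives 12700 nM, the only true number so far. Compound 1 `COc1cc(C2CC(c3ccccc3)=NN2C(=O)OCc2ccccc2)cc(OC)c1OC` gives > 10000 nM, which is a limit. Compound 2 `COc1cccc(C2=NN(C(=O)OCc3ccccc3)C(c3cc(OC)c(OC)c(OC)c3)C2)c1` gives > 10000 nM, also a limit. For the measured compounds named here, the one measured step, methoxy in place of hydrogen on an aromatic carbon, is a step that the two limits leave unreadable from compound 1 to compound 2. Compound 4 `COc1ccc(C2=NN(C(=O)OCc3ccccc3)C(c3cc(OC)c(OC)c(OC)c3)C2)cc1` departs from compound 3 by phenyl in place of ethyl on a saturated chain carbon bound to an oxygen next to a carbonyl group, which turns propoxycarbonyl into benzyloxycarbonyl. Compound 1 and compound 2 also carry benzyloxycarbonyl and stand at the limit of > 10000 nM in this assay, at which 2 of the 3 values shown sit, so no clear gain in growth inhibition is expected. The estimated step is a 1.1-fold lower number from compound 3 to compound 4 (0.02 log units; within the scatter), no larger than the usual scatter. Compound 4 is expected at 12000 nM, with an estimated range of 5000 nM to 30000 nM.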

Compound 4, concentration for 50% growth inhibition: > 10000 nM
Compound 4: no number, only a limit; the forecaster's own chance of this, stated with the estimate: 60%; the middle value does not contradict the limit.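

Compound 4 gives only a limit, as do compound 1 and compound 2, so its steps from compound 1, compound 2 and compound 3 cannot be read. How far these compounds truly differ in this assay stays open: the limit of > 10000 nM in this assay, at which 3 of the 4 values shown sit.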